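The compounds below may be only part of what the source reports. "The series", "measured", "known", "first", "only" and "open" are said of these compounds alone.

Compound 1 `CCn1ccnc1-c1cc(OC)c(OC)c(OC)c1` is the starting point, and its only result comes from a functional assay on MDA-MB-468 cells (Homo sapiens) for antiproliferative activity, read by MTT assay, with a stated time of 72 h; a higher number here means a weaker inhibitor, a lower number a stronger inhibitor. There compound 1 gives > 100000 nM, which is a limit of the assay and not a number. Compound 2 `COc1cc(-c2nccn2C(C)C)cc(OC)c1OC` gives > 100000 nM in this assay, which is also a limit. The whole record so far is the limit of > 100000 nM in this assay, at which 2 of the 2 values shown sit.

Within the data shown here, the one measured change is a step that the two limits leave unreadable from compound 1 to compound 2, so it offers no size to carry forward.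

Compound 3 `CCCCCn1ccnc1-c1cc(OC)c(OC)c(OC)c1` differs from compound 1 as follows: propyl in place of hydrogen on a saturated chain carbon, two bonds along the chain from an aromatic nitrogen. Put another way, an ethyl becomes a pentyl. With no readable step to guide the estimate, no clear shift in either direction is expected in this assay, and another limit is the likeliest report. The expected change is a number no higher from compound 1 to compound 3 (the limit leaves the size open). The estimated value for compound 3 is 100000 nM, with an expected range from 30000 nM to 200000 nM.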

Compound 3, half-maximal inhibitory concentration: 57900 nM
Compound 3: the middle estimate sits 1.7-fold (0.24 log units) above what was measured; measured number inside the range.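

Compound 3 is the first compound shown to give a readable number rather than a limit in this assay, so this position on the aromatic nitrogen can carry a chain that brings the result into the measurable range. Replacing ethyl with pentyl gives an at least 1.7-fold lower number from compound 1 to compound 3 (0.23 log units; that floor lies within the scatter), and replacing isopropyl with pentyl gives an at least 1.7-fold lower number from compound 2 to compound 3 (0.23 log units; that floor lies within the scatter). Both steps are floors and not full sizes, so the real gain could be larger, but what can be read so far does not clear the scatter, and most of the record stays at the limit: the limit of > 100000 nM in this assay, at which 2 of the 3 values shown sit.

On these data alone, whether a longer chain than pentyl would lower the number further remains open. So does the effect of a chain ending in an amine or a carboxylic acid at this position.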